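Fluorophenyl isomers on the sulfonyl sulfur

A few compounds are considered here, and "the series" means these few. Any claim that something is new, unique, unknown or untested is made for them only; others in the source may bear on it.

In an ADME assay on HEK293 cells (Homo sapiens) for cytotoxicity, read by resazurin assay, with a stated time of 48 h (on this read-out lower numbers stand for higher toxicity in this test and higher numbers for lower toxicity in this test), compound 1 (`O=S(=O)(Nc1ccc(-c2nc3ccccc3o2)cc1)c1cccc(F)c1`) reads > 100000 nM as a limit of the assay and not a number. Compound 4 (`O=S(=O)(Nc1ccc(-c2nc3ccccc3o2)cc1)c1ccccc1F`) carries 2-fluorophenyl in place of 3-fluorophenyl on a sulfonyl sulfur and is not yet measured. The nearest evidence comes from a core unlike that of compound 1: compound 2 (`Cc1ccccc1S(=O)(=O)Nc1ccc2oc(-c3ccccc3)nc2c1`) gives 57000 nM and compound 3 (`COc1cccc(S(=O)(=O)Nc2ccc3oc(-c4ccccc4)nc3c2)c1`) gives 63000 nM in this read-out. Within the data shown here, their exchange on the sulfonyl sulfur gives a 1.1-fold higher number from compound 2 to compound 3 (0.04 log units; within the scatter) as the only measured step there, so no change beyond the scatter is expected in this assay here. The expected step is an at least 1.1-fold lower number from compound 1 to compound 4 (0.04 log units; that floor lies within the scatter) as an estimate. Compound 4 is estimated at 90000 nM with a range of 45000 nM to 180000 nM and may again read as a limit.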

Compound 4, half-maximal cytotoxic concentration: > 100000 nM
Compound 4: no number, only a limit (the forecaster's own chance of this, stated with the estimate: 55%); middle value at least 1.1-fold (0.04 log units) from the limit.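

Compound 1 and compound 4 both read as limits and not numbers in this assay, so no step between them can be read: the limit of > 100000 nM in this assay, at which 2 of the 4 values shown sit.

The compounds shown leave open whether 2-fluorophenyl in place of 3-fluorophenyl on a sulfonyl sulfur changes the read-out at all.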